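The compounds below may be only part of what the source reports. "The series", "measured", "known", "first", "only" and "open" are said of these compounds alone.

Compound 1, `CCCCNc1nc(N)nc2cccnc12`, gives 1900 nM in an assay on tissue (PBMC cells) for agonist activity at Toll-like receptor 8 (Homo sapiens), with a stated time of 24 h; a lower number here means that less compound is needed, a higher number that more compound is needed for the effect.
Compound 2, `CCCC(C)Nc1nc(N)nc2cccnc12`, gives 3100 nM in this assay.
Compound 3, `CCCC[C@H](CO)Nc1nc(N)nc2cccnc12`, gives 790 nM in this assay.

Compound 1 and compound 2 share a core and differ only by methyl in place of hydrogen on a saturated chain carbon bound to a nitrogen on an aromatic ring and a saturated chain carbon. The step of a 1.6-fold higher number from compound 1 to compound 2 (0.21 log units; within the scatter) shows that adding this methyl left the readout essentially where it was. Compound 3 carries a different side chain on the same core; the difference between the core of compound 1 and the core of compound 3 is not broken down here. What the two values show is that compound 3 stands with the lowest number of the three, and its steps to compound 1 and to compound 2 both lie beyond the scatter.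

Compound 4, `CCCCC[C@H](CO)Nc1nc(N)nc2cccnc12`, has not yet been measured. It differs from compound 3 by methyl in place of hydrogen on a saturated chain carbon, five bonds along the chain from a nitrogen on an aromatic ring. Among the measured compounds shown here, this is the same kind of change as the one from compound 1 to compound 2, a methyl entering in place of a hydrogen, but the place is not the same: in the earlier pair the carbon is bound to a nitrogen on an aromatic ring and a saturated chain carbon, whereas here the carbon sits five bonds along the chain from a nitrogen on an aromatic ring. Because the earlier methyl gave a 1.6-fold higher number from compound 1 to compound 2 (0.21 log units; within the scatter), a small step is expected here too, so compound 4 is expected to give a 1.1-fold higher number from compound 3 to compound 4 (0.06 log units; within the scatter) in this assay, which rests on a single precedent at a different place and is therefore uncertain. Compound 4 is estimated at 900 nM, with a likely range from 350 nM to 2500 nM.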

Compound 4, half-maximal effective concentration: 3330 nM
Estimate against measurement, compound 4: 3.7-fold (0.57 log units) below; measured number above the stated range.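

In this assay, the methyl entering on the side chain of compound 3, on a saturated chain carbon five bonds along the chain from a nitrogen on an aromatic ring, gives a 4.2-fold higher number from compound 3 to compound 4 (0.62 log units; beyond the scatter). Set beside the earlier methyl step, this result cannot be told apart from it, even though only the newer step lies beyond the scatter on its own: the same change on two cores in this assay, a 1.6-fold higher number (0.21 log units; within the scatter) from compound 1 to compound 2 and a 4.2-fold higher number (0.62 log units; beyond the scatter) from compound 3 to compound 4, 2.6-fold (0.41 log units) apart, within the scatter of two such steps. This shows neither that the change carries from one core to another with a fixed size nor that its size depends on the core, for each step rests on a single pair and the methyl enters at a different place in each.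

The compounds shown leave open how the number would move along a longer chain than that of compound 4, and so whether the step to compound 4 belongs to a trend in chain length or stands alone. They also leave open what the hydroxyl contributes to the number of compound 3, and how an amine or a carboxylic acid in its place would read in this assay.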